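The source may hold more compounds than are shown below. What is called first, only, known or untested is meant among the compounds shown, and "the series" means these compounds.

Of the compounds shown here, three have been measured in an assay on isolated protein with Bile acid receptor (Homo sapiens) as the target; on this read-out higher numbers stand for an effect only at larger amounts of compound and lower numbers for an effect already at smaller amounts.

Compound 1, `COC(=O)/C=C/c1cccc(N(Cc2ccc(/C=C/c3ccccc3F)cc2)C(=O)C2CCCCC2)c1`, gives 64 nM.
Compound 2, `COC(=O)/C=C/c1cccc(N(Cc2ccc(-c3ccc(SC)cc3)cc2)C(=O)C(C)C)c1`, gives 51 nM.
Compound 3, `COC(=O)/C=C/c1cccc(N(Cc2ccc(Br)cc2)C(=O)C2CCCCC2)c1`, gives only a limit of the assay, > 1000 nM.

Compound 3 thus stands at the edge of what this assay can report, as recorded in the limit of > 1000 nM in this assay, at which 1 of the 3 values shown sits; its true number is not known, only that it lies at or past the limit. Compound 4, `COC(=O)/C=C/c1cccc(N(Cc2ccc(-c3ccc(SC)cc3)cc2)C(=O)C2CCCCC2)c1`, has not been measured yet. It arises from compound 3 by one change: 4-(methylsulfanyl)phenyl in place of bromo on an aromatic carbon.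

Going by the values given here, one measured step bears directly on this. The reverse change, bromo in place of 2-(2-fluorophenyl)ethenyl, gave an at least 15-fold higher number from compound 1 to compound 3 (1.19 log units; beyond the scatter). Among the compounds with values here, compound 2 carries the same 4-(methylsulfanyl)phenyl group that enters here, on a different amide, and gives 51 nM; no step links it to compound 4, so it only shows that this group is compatible with a low number.

On that basis a large move in the opposite direction to the measured step is expected for compound 4, well beyond the scatter, towards the numbers of compound 1 and compound 2. The estimate for compound 4 is 55 nM, between 20 nM and 200 nM, which would mean an expected step of an at least 18-fold lower number from compound 3 to compound 4 (1.25 log units; beyond the scatter).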

Compound 4, half-maximal effective concentration: 69 nM
Compound 4: middle estimate off by 1.3-fold (0.10 log units), on the low side, and the stated range covers the measured number.
By their numbers in this assay, from the lowest: compounds 2, 1 and 4 (each within the scatter of the next). At a limit, above all of these: compound 3.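

Replacing bromo with 4-(methylsulfanyl)phenyl on the same cyclohexyl amide gives an at least 14-fold lower number from compound 3 to compound 4 (1.16 log units; beyond the scatter), so in this assay the group on this aromatic carbon can decide whether a low number is reached at all, and the earlier step to compound 3 now has a counterpart with a second, different group. Compound 3 is recorded only as a limit, so the true size of this step stays unknown: the limit of > 1000 nM in this assay, at which 1 of the 4 values shown sits.

The two large groups at this place cannot be told apart, with a 1.1-fold higher number from compound 1 to compound 4 (0.03 log units; within the scatter), and the amide can carry either of two groups without a clear change, with a 1.4-fold higher number from compound 2 to compound 4 (0.13 log units; within the scatter), both steps lying within the scatter.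

On these data alone, what remains open is which part of the entering group matters: a plain phenyl or a 4-methoxyphenyl would show whether the ring alone is enough or the sulfur-bearing end also counts. As far as these compounds go, it is also open how a short ethyl chain at this place would compare, and whether the low numbers would hold with a carboxylic acid in place of the methyl ester.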